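The compounds below may be only part of what the source reports. "The series", "measured", "known", "first", "only" and "open" are said of these compounds alone.

Measured compounds:
- Compound 1 `Cc1c(C(=O)N/N=C/c2ccc(N(C)C)cc2)no[n+]1[O-]`: 129000 nM
- Compound 2 `O=C(N/N=C/c1c(-c2ccccc2)no[n+]1[O-])c1cnn(-c2ccccc2)c1`: 41700 nM
- Compound 3 `Cc1c(/C=N/NC(=O)c2no[n+]([O-])c2C)no[n+]1[O-]`: > 400000 nM

In an ADME assay on J774.1 cells (Mus musculus) for cytotoxicity, read by MTT assay, with a stated time of 48 h (on this read-out lower numbers stand for stronger inhibition and higher numbers for weaker inhibition), compound 1 gives 129000 nM, the highest of the two numbers reported. Its nearest neighbour is compound 2, which in this assay gives 41700 nM, a gap that lies beyond the usual scatter. Compound 3 gives only a limit in this assay, > 400000 nM, and the limit at the limit of > 400000 nM in this assay, at which 1 of the 3 values shown sits, is reached by one of the three values shown.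

Compound 4 `Cc1c(C(=O)N/N=C/c2ccc([N+](=O)[O-])cc2)no[n+]1[O-]` has not yet been measured. It differs from compound 1 in one place: nitro in place of dimethylamino on an aromatic carbon. Among the measured compounds shown here, no step between measured compounds touches this position, so the effect of the exchange is unknown from the present set. The closest guide is compound 1 itself at 129000 nM. With nothing to suggest a shift in either direction, compound 4 is expected to stay within the scatter of compound 1, giving an estimated step of a 1.2-fold lower number from compound 1 to compound 4 (0.07 log units; within the scatter). Compound 4 is therefore estimated at 110000 nM in this assay, with a range from 35000 nM to 400000 nM.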

Compound 4, half-maximal inhibitory concentration: > 300000 nM
Compound 4 gave a limit, no number (the forecaster's own chance of this, stated with the estimate: 25%); middle value at least 2.7-fold (0.43 log units) from the limit.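

The exchange of dimethylamino for nitro on an aromatic carbon, para to a large group, gives the first view of this position, and the number moves: an at least 2.3-fold higher number from compound 1 to compound 4 (0.36 log units; beyond the scatter) in this assay. In this assay compound 4 gives > 300000 nM, which is a limit and not a number. As far as these compounds go, the position on the six-membered ring therefore bears on the read-out, and this change moves it towards weaker inhibition, though the full size of the step stays unknown.

With a single exchange at this place, the compounds shown do not tell whether the loss of dimethylamino or the arrival of nitro sets the shift. From the compounds shown here alone, how a methoxy group, a primary amine, a carboxylic acid or a plain hydrogen would read here also remains open.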